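Swapping the halogenated phenyl on a tetrazole-linked anilide

The source may hold more compounds than are shown below. What is called first, only, known or untested is meant among the compounds shown, and "the series" means these compounds.

Compound 3 `COc1ccc(Nc2nnnn2-c2ccc(F)cc2)cc1` gives 101000 nM in an ADME assay on HaCaT cells (Homo sapiens) for cytotoxicity, read by MTT assay, with a stated time of 72 h; a higher number here means a weaker inhibitor, a lower number a stronger inhibitor. Its number is the lowest of the three shown, yet compound 1 `COc1ccc(Nc2nnnn2-c2ccc(Br)cc2)cc1` with 103000 nM and compound 2 `COc1ccc(-n2nnnc2Nc2ccccc2Cl)cc1` with 134000 nM both lie within the scatter of it, so no ordering can be claimed. Among the measured compounds shown here, the one measured step that touches the same place, a 1.0-fold lower number from compound 1 to compound 3 (0.01 log units; within the scatter), left the number essentially unchanged. Compound 4 `COc1ccc(Nc2nnnn2-c2cccc(Cl)c2)cc1` differs from compound 3 by 3-chlorophenyl in place of 4-fluorophenyl on an aromatic nitrogen. For the measured compounds named here, no measured pair covers a 3-chlorophenyl at this place, so the expectation rests on that single flat step. The number for compound 4 is therefore expected to stay within the scatter, a step of a 1.0-fold higher number from compound 3 to compound 4 (0.02 log units; within the scatter), estimated at 105000 nM with a range from 60000 nM to 180000 nM.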

Compound 4, half-maximal inhibitory concentration: 103000 nM
The estimate for compound 4 lay 1.0-fold (0.01 log units) above the measured number; measured number inside the range.
By their numbers in this assay, from the lowest: compounds 3, 1, 4 and 2 (each within the scatter of the next).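

The step from 4-fluorophenyl to 3-chlorophenyl on the aromatic nitrogen stays within the scatter (a 1.0-fold higher number from compound 3 to compound 4 (0.01 log units; within the scatter)), and the step from 4-bromophenyl to 3-chlorophenyl shows the same flat result (no change at the digits printed from compound 1 to compound 4 (within the scatter)). Earlier, only the halogen had changed at this place; these steps show that a change of halogen together with its place on the phenyl also leaves the number flat. Nothing available explains this flatness. On these data alone, all these groups are halogen-bearing phenyls, so it remains open whether an amine, a carboxylic acid or a longer chain on that phenyl would shift the number.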